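This account rests on a few compounds, and the source may have more. Where it says the series, first, only, none or still open, it means among the compounds named here.

Measured so far:
- compound 1, `COc1ccc(C(=O)Nc2nc3c(OC)cccc3s2)cc1`: 2.11 ug/mL
- compound 2, `COc1cccc2sc(NC(=O)c3ccc(C#N)cc3)nc12`: > 10 ug/mL

In a functional assay on SK-HEP1 cells (Homo sapiens) for antiproliferative activity, read by sulforhodamine B assay (on this read-out higher numbers stand for weaker inhibition of growth and lower numbers for stronger inhibition of growth), compound 1 gives 2.11 ug/mL. For compound 2 the recorded value of > 10 ug/mL is a limit of the assay and not a number, as noted at the limit of > 10 ug/mL in this assay, at which 1 of the 2 values shown sits. Compound 2 therefore stands only at this limit, with no exact figure on record. Among the compounds with values here, the one measured step, an at least 4.7-fold higher number from compound 1 to compound 2 (0.67 log units; beyond the scatter), shows that cyano in place of methoxy on an aromatic carbon moved the result toward weaker growth inhibition.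

Compound 3, `COc1cccc2sc(NC(=O)c3ccc([N+](=O)[O-])cc3)nc12`, differs from compound 2 by nitro in place of cyano on an aromatic carbon. Within the data shown here, no measured step covers nitro, so the only guide is that compound 2 already sits at the limit. Compound 3 is expected to remain near that limit, with an estimated value of 12 ug/mL and a range from 4 ug/mL to 30 ug/mL. The expected step that the limit leaves unreadable from compound 2 to compound 3 is estimated to lie within the scatter, and a limit rather than a number is thought likely again.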

Compound 3, concentration for 50% growth inhibition: > 10 ug/mL
Compound 3 was reported as a limit; the forecaster's own chance of this, stated with the estimate: 60%; the middle value does not contradict the limit.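

In this assay, putting a nitro group where methoxy stood gives an at least 4.7-fold higher number from compound 1 to compound 3 (0.67 log units; beyond the scatter). Cyano is therefore no longer the only replacement at this place, para to a large group, that goes with weaker growth inhibition than methoxy. The step from cyano to nitro cannot be read, and no order can be given between compound 2 and compound 3, because each is recorded as a limit and not a number: the limit of > 10 ug/mL in this assay, at which 2 of the 3 values shown sit.

The compounds shown leave open how far beyond the limit compound 2 and compound 3 lie, and whether methoxy is unusual in giving a measurable value here. An amine, a hydroxyl group or a longer ether chain at this place would show whether a readable value can be kept without methoxy.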